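Compound 3 to compound 4: replacing the 1,3-oxazol-2-yl group

The compounds below may be only part of what the source reports. "The series", "measured", "known", "first", "only" and "open" are said of these compounds alone.

Of the compounds shown here, three on the shared core have been read in a physicochemical assay for permeability, using PAMPA; on this read-out higher numbers stand for higher permeability and lower numbers for lower permeability. Compound 1 `Cc1ccc([C@@H](C)Oc2cc3oc(=O)n(CCC(=O)O)c3cc2Cl)nc1` gives 22 nm/s. Compound 2 `C[C@@H](Oc1cc2oc(=O)n(CCC(=O)O)c2cc1Cl)c1ccc(Cl)cn1` gives 60 nm/s, and a 2.7-fold higher number from compound 1 to compound 2 (0.44 log units; beyond the scatter) with chloro in place of methyl on an aromatic carbon. Compound 3 `C[C@@H](Oc1cc2oc(=O)n(CCC(=O)O)c2cc1Cl)c1ncco1` reads < 3 nm/s, which is a limit of the assay and not a number.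

Compound 4 `Cc1ccnc([C@@H](C)Oc2cc3oc(=O)n(CCC(=O)O)c3cc2Cl)c1` differs from compound 3 at one place, on a saturated chain carbon bound to an oxygen on an aromatic ring and a saturated chain carbon: 4-methylpyridin-2-yl in place of 1,3-oxazol-2-yl on a saturated chain carbon bound to an oxygen on an aromatic ring and a saturated chain carbon.

Among the compounds with values here, two measured steps bear on this change, both with 1,3-oxazol-2-yl as the entering group: an at least 7.3-fold lower number from compound 1 to compound 3 (0.86 log units; beyond the scatter) and an at least 20-fold lower number from compound 2 to compound 3 (1.30 log units; beyond the scatter). Both lie beyond the scatter. Within the data shown here, no measured compound carries 4-methylpyridin-2-yl, so compound 1 with 5-methylpyridin-2-yl at 22 nm/s is the closest guide, and compound 2 shows that a change on that group alone can move this assay modestly.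

An upward move of at least modest size is therefore expected, estimated as an at least 6.6-fold higher number from compound 3 to compound 4 (0.82 log units; beyond the scatter). The estimated value for compound 4 is 20 nm/s, with an expected range of 7 nm/s to 50 nm/s.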

Compound 4, apparent permeability: < 3 nm/s
Compound 4: no number, only a limit; the forecaster's own chance of this, stated with the estimate: 5%; at least 6.6-fold (0.82 log units) between middle value and limit.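

In this assay compound 4 reads < 3 nm/s, which is a limit of the assay and not a number. With 4-methylpyridin-2-yl at this place there is an at least 7.3-fold lower number from compound 1 to compound 4 (0.86 log units; beyond the scatter), against 5-methylpyridin-2-yl, and an at least 20-fold lower number from compound 2 to compound 4 (1.30 log units; beyond the scatter), against 5-chloropyridin-2-yl, so a pyridin-2-yl group as such does not keep the read-out clear of the limit, and the group's substitution decides the outcome across compound 1, compound 2 and compound 4. The step between compound 3 and compound 4 cannot be read, so the change away from 1,3-oxazol-2-yl has no visible size in either direction: the limit of < 3 nm/s in this assay, at which 2 of the 4 values shown sit.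

The compounds shown leave open how far compound 3 and compound 4 lie from each other, and whether the gap to compound 1 comes from the site of the methyl alone. Also open, from the compounds shown here alone, is what an unsubstituted pyridin-2-yl or a 4-chloropyridin-2-yl group would read at this place, which would separate the site of a substituent from its kind.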